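The source may report more compounds than this note shows. Statements on the series, on what has been measured and on what is new or still open speak of the compounds shown alone.

Measured compounds:
- compound 1, `C=CC1=C(C(=O)NCc2ccccc2F)C(c2ccc(F)cc2)OC1`, in a functional assay on A549 cells (Homo sapiens) for cytotoxicity, read by MTT assay, with a stated time of 24 h; a higher number here means a weaker inhibitor, a lower number a stronger inhibitor: > 100000 nM, a limit of the assay only
- compound 2, `C=CC1=C(C(=O)Nc2ccc(C)cc2)C(c2ccc(OC)cc2)OC1`, in this assay: > 100000 nM, again a limit
- compound 3, `C=CC1=C(C(=O)NCc2ccccc2F)C(c2ccc(OC)cc2)OC1`, in this assay: > 100000 nM, again a limit

Compound 1 thus stands at the limit, where all three measured values sit (the limit of > 100000 nM in this assay, at which 3 of the 3 values shown sit). The account follows the change to compound 4, `C=CC1=C(C(=O)NCc2ccccc2)C(c2ccc(F)cc2)OC1`: hydrogen in place of fluoro on an aromatic carbon. Among the measured compounds shown here, no measured step changes exactly this group. The two steps that exist, a step that the two limits leave unreadable from compound 1 to compound 3 and a step that the two limits leave unreadable from compound 2 to compound 3, are both unreadable, so they give no size to lean on. Compound 4 is therefore expected to stay at the limit, estimated at 150000 nM (range 50000 nM to 500000 nM). The expected step is a step that the limit leaves unreadable from compound 1 to compound 4, which means no change beyond the scatter.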

Compound 4, half-maximal inhibitory concentration: > 100000 nM
Compound 4 was reported as a limit; the forecaster's own chance of this, stated with the estimate: 85%; the middle value is on the limit's open side.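

Compound 1 and compound 4 are both reported only as limits in this assay, so no step can be read between them: the limit of > 100000 nM in this assay, at which 4 of the 4 values shown sit.

The compounds shown leave open whether any change to the shared core would give a measurable value in this assay.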